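The source may report more compounds than this note shows. Statements on the series, on what has been measured and on what is new or still open speak of the compounds shown alone.

Compound 1 `COc1cc2c(Oc3ccc(NC(=O)c4nn(-c5cccc(F)c5)c(=O)cc4C)cc3F)ccnc2cc1OCCCN1CCCC1` in a functional assay on NCI-H460 cells (Homo sapiens) for inhibition, read by MTT assay, with a stated time of 72 h (a lower number here means a stronger inhibitor, a higher number a weaker inhibitor), gives 280 nM.
Compound 2 `COc1cc2c(Oc3ccc(NC(=O)c4nn(-c5cccc(F)c5)c(=O)cc4C)cc3F)ccnc2cc1OCCCN1CCCCC1` in this assay gives 360 nM.
Compound 3 `COc1cc2c(Oc3ccc(NC(=O)c4nn(-c5ccc(Cl)cc5)c(=O)cc4C)cc3F)ccnc2cc1OCCCN1CCCC1` in this assay gives 360 nM.

Compound 4 `COc1cc2c(Oc3ccc(NC(=O)c4nn(-c5ccc(Cl)cc5)c(=O)cc4C)cc3F)ccnc2cc1OCCCN1CCCCC1` has not yet been measured. It differs from compound 3 in one place: piperidin-1-yl in place of pyrrolidin-1-yl on a saturated chain carbon, three bonds along the chain from an oxygen on an aromatic ring. The same change has been made once before among these compounds, from compound 1 to compound 2: piperidin-1-yl in place of pyrrolidin-1-yl on a saturated chain carbon, three bonds along the chain from an oxygen on an aromatic ring. That step read a 1.3-fold higher number from compound 1 to compound 2 (0.11 log units; within the scatter). The core on which compound 4 is built differs from the core of compound 1 in a second place: 4-chlorophenyl in place of 3-fluorophenyl on an aromatic nitrogen. That difference alone gave a 1.3-fold higher number from compound 1 to compound 3 (0.11 log units; within the scatter). For compounds 2 and 3 no step is given; their two values stand level at the digits shown.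

For the measured compounds named here, with only one earlier example of the change in hand, the expectation for compound 4 can rest on nothing more than that example. Because the earlier step was a 1.3-fold higher number from compound 1 to compound 2 (0.11 log units; within the scatter), a step of about the same size is expected here, a 1.3-fold higher number from compound 3 to compound 4 (0.11 log units; within the scatter), which would still lie within the scatter of repeated measurement. On that basis compound 4 is estimated at 460 nM in this assay, with a likely range from 240 nM to 900 nM.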

Compound 4, half-maximal inhibitory concentration: 460 nM
Compound 4: middle estimate and measured number agree at the digits printed, within the range that was stated.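

In this assay, putting piperidin-1-yl in place of pyrrolidin-1-yl on the core carrying 4-chlorophenyl gives a 1.3-fold higher number from compound 3 to compound 4 (0.11 log units; within the scatter), and this matches the step seen on the core carrying 3-fluorophenyl: the same change on two cores in this assay, a 1.3-fold higher number (0.11 log units; within the scatter) from compound 1 to compound 2 and a 1.3-fold higher number (0.11 log units; within the scatter) from compound 3 to compound 4, 1.0-fold (0.00 log units) apart, within the scatter of two such steps. The other change, 4-chlorophenyl in place of 3-fluorophenyl on an aromatic nitrogen, gives a 1.3-fold higher number from compound 2 to compound 4 (0.11 log units; within the scatter), and it also matches its earlier step: the same change on two cores in this assay, a 1.3-fold higher number (0.11 log units; within the scatter) from compound 1 to compound 3 and a 1.3-fold higher number (0.11 log units; within the scatter) from compound 2 to compound 4, 1.0-fold (0.00 log units) apart, within the scatter of two such steps. For the compounds shown here, these four compounds therefore show each change reading the same on two cores, but every step lies within the scatter, so they show only that neither change moved the number measurably here, not that a larger step would carry over in the same way.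

Going by these compounds, it remains open whether this holds for other amines at the end of the chain, such as morpholine or dimethylamine, or for a longer chain than propyl. Other groups on the aromatic nitrogen, such as an unsubstituted phenyl or a pyridine ring, also remain to be seen in this assay.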